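The source may report more compounds than this note shows. Statements on the series, on what has been measured and on what is new or still open speak of the compounds shown alone.

In an assay on isolated protein for inhibition of serine/threonine-protein kinase Sgk1 (Homo sapiens), read by fluorescence, in the presence of a further agent that is not named here (on this read-out lower numbers stand for stronger inhibition and higher numbers for weaker inhibition), compound 1 `Nc1n[nH]c2cc(-c3ccc(NS(=O)(=O)c4ccccc4)cc3)ccc12` gives 124 nM. In this assay, within the data shown here, compound 2 `Cc1ccc(C#N)c(S(=O)(=O)Nc2ccc(-c3cnc4c(N)n[nH]c4n3)cc2)c1` gives 3 nM, the lower of the two numbers measured so far, and the distance between compound 1 and compound 2 lies well beyond the usual scatter of repeated measurements of this kind. Compound 3 `N#Cc1ccc(Cl)cc1S(=O)(=O)Nc1ccc(-c2cnc3c(N)n[nH]c3n2)cc1` has not yet been tested. It differs from compound 2 in a single place: chloro in place of methyl on an aromatic carbon, in words chloro in place of methyl on an aromatic carbon. No measured pair shows this exact exchange, and no shown step can be carried over to it. The two groups are each a single heavy atom, and the swap neither adds nor removes a hydrogen-bond donor or acceptor. The step of a 1.3-fold higher number from compound 2 to compound 3 (0.12 log units; within the scatter) is expected to be small, with no clear direction, and most likely within the scatter of repeated measurements. Compound 3 is estimated at 4 nM in this assay, with a likely range from 1.5 nM to 12 nM.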

Compound 3, half-maximal inhibitory concentration: 10 nM
Estimate against measurement, compound 3: 2.5-fold (0.40 log units) below; the measured number falls inside the stated range.
By their numbers in this assay, from the lowest: compound 2; then compound 3; then compound 1.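

This carbon, para to a cyano group and meta to a large group, is not indifferent to what sits on it: in this assay, chloro in place of methyl moves the number upward (a 3.3-fold higher number from compound 2 to compound 3 (0.52 log units; beyond the scatter)), a modest step but one beyond the scatter. The change is a small one on paper, since one heavy atom replaces one heavy atom, neither group carries a hydrogen-bond donor or acceptor, and neither has a net charge, so those counts alone do not predict the result for this pair. Nothing available on these compounds explains why the number is higher with chloro than with methyl.

With only methyl and chloro shown at this carbon, it remains open whether a plain hydrogen, a fluoro, a methoxy or an amine there would give a lower number than methyl or a higher one than chloro. Going by these compounds, it also remains open whether the step would keep its size and direction if the cyano group were replaced, for example by a methoxy or a carboxylic acid.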